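The compounds below may be only part of what the source reports. "The series", "measured", "known", "first", "only" and "open" are said of these compounds alone.

Compound 1 `Nc1cc(N)c2nc(-c3ccccc3)c(Oc3ccc(Cl)c(Cl)c3)nc2c1`: 91200 nM
Compound 2 `COc1cc(CNc2nc3cc(N)cc(N)c3nc2-c2ccccc2)cc(OC)c1OC`: 6310 nM
Compound 3 `CCOC(=O)[C@H](CCC(=O)O)NC(=O)c1ccc(CNc2nc3cc(N)cc(N)c3nc2-c2ccccc2)cc1`: < 100000 nM

Of the compounds shown here, three sharing one core have been tested in a functional assay on A498 cells (Homo sapiens) for inhibition, read by sulforhodamine B assay, with a stated time of 48 h; a higher number here means a weaker inhibitor of growth, a lower number a stronger inhibitor of growth. Compound 1 gives 91200 nM, the higher of the two numbers; compound 2 sits at a lower number, 6310 nM, a gap beyond the usual scatter. Compound 3 gives < 100000 nM, which is a limit of this assay rather than a number, namely (the limit of < 100000 nM in this assay, at which 1 of the 3 values shown sits). Compound 4 `Nc1cc(N)c2nc(-c3ccccc3)c(NCc3ccc(F)cc3)nc2c1` is not yet measured; it differs from compound 1 in one place ((4-fluorobenzyl)amino in place of 3,4-dichlorophenoxy on an aromatic carbon). Because compound 2 is also amine-linked at the varied position and gives 6310 nM, the step of a 9.1-fold lower number from compound 1 to compound 4 (0.96 log units; beyond the scatter) is expected to go downward, toward stronger growth inhibition, beyond the scatter. Compound 4 is expected to give about 10000 nM, most likely between 3000 nM and 40000 nM.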

Compound 4, concentration for 50% growth inhibition: 17000 nM
The estimate for compound 4 lay 1.7-fold (0.23 log units) below the measured number, within the range that was stated.
By their numbers in this assay, from the lowest: compound 2; then compound 4; then compound 1.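

At this position on the shared core, putting (4-fluorobenzyl)amino in place of 3,4-dichlorophenoxy gives a 5.4-fold lower number from compound 1 to compound 4 (0.73 log units; beyond the scatter), the first one-place comparison among these compounds, and it points toward stronger growth inhibition. The entering group brings a hydrogen-bond donor that the leaving group lacks, and it also swaps oxygen for nitrogen and adds a carbon, so several things change at once. No measurement shown explains this step. On these data alone, it remains open which of these changes matters. A 3,4-dichloroanilino group, an unsubstituted benzylamino group or a longer chain on the amine could help separate them.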